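A few compounds are considered here, and "the series" means these few. Any claim that something is new, unique, unknown or untested is made for them only; others in the source may bear on it.

Three compounds sharing one core differ only in the group on the saturated chain carbon bound to the oxygen on the aromatic ring. In a functional assay on HCT-116 cells (Homo sapiens) for cytotoxicity, read by MTT assay, with a stated time of 48 h (on this read-out higher numbers stand for weaker inhibition and lower numbers for stronger inhibition), compound 1 `CC(C)COc1ccc2c(Cl)ccnc2c1` gives 2490 nM, compound 2 `CCCCOc1ccc2c(Cl)ccnc2c1` gives 2740 nM and compound 3 `Clc1ccnc2cc(OCc3ccccc3)ccc12` gives 2470 nM. Compound 3 holds the lowest of the three numbers in this assay, yet its separation from each of the other two lies within the scatter. The steps of a 1.1-fold higher number from compound 1 to compound 2 (0.04 log units; within the scatter), a 1.0-fold lower number from compound 1 to compound 3 (0.00 log units; within the scatter) and a 1.1-fold lower number from compound 2 to compound 3 (0.05 log units; within the scatter) are all within the scatter, so exchanging isopropyl, propyl and phenyl at this place has left the read-out unchanged within the noise.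

Compound 4 `CCOc1ccc2c(Cl)ccnc2c1` has not been measured. Relative to compound 3 the change is methyl in place of phenyl on a saturated chain carbon bound to an oxygen on an aromatic ring. All three measured steps concern the same place and none of them moved the number beyond the scatter, though methyl is smaller than any group tried so far. The expectation is therefore no step beyond the scatter, and a 1.1-fold higher number from compound 3 to compound 4 (0.04 log units; within the scatter) is the estimated step. Compound 4 is estimated at 2700 nM in this assay, with a range from 1400 nM to 5500 nM.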

Compound 4, half-maximal inhibitory concentration: 3160 nM
Beside the measured number, compound 4's estimate is 1.2-fold (0.07 log units) below it; measured number inside the range.
By their numbers in this assay, from the lowest: compounds 3, 1, 2 and 4 (each within the scatter of the next).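

In this assay, methyl, the smallest group so far at this place, stays within the scatter of all three larger groups: a 1.3-fold higher number from compound 3 to compound 4 (0.11 log units; within the scatter) and a 1.3-fold higher number from compound 1 to compound 4 (0.10 log units; within the scatter). The chain change that gives hydrogen in place of ethyl also stays within it, with a 1.2-fold higher number from compound 2 to compound 4 (0.06 log units; within the scatter), and the loss of the six-membered aromatic ring of carbon only from phenyl to methyl does not move the read-out beyond the noise, so neither that ring nor a branched or longer group is required here to keep the number within this range. Nothing available accounts for this lack of response.

On these data alone, it remains open whether the read-out also holds with a much longer chain such as octyl, or with an amine or a carboxylic acid at the end of the chain. As far as these compounds go, it also remains open whether replacing the chloro group of the shared core with an amine would shift the number.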